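Dropping the ketone from the amine side chain

This account rests on a few compounds, and the source may have more. Where it says the series, first, only, none or still open, it means among the compounds named here.

Measured compounds:
- Compound 1 `COC(=O)C(=O)CNC1=CS(=O)(=O)O[C@@]12[C@@H](CO[Si](C)(C)C(C)(C)C)O[C@@H](n1cc(C)c(=O)n(C)c1=O)[C@@H]2O[Si](C)(C)C(C)(C)C`: in a functional assay on HEL cells (Homo sapiens) (a higher number here means that more compound is tolerated, a lower number that less compound is tolerated), compound 1 gives > 200000 nM, which is a limit of the assay.
- Compound 2 `CCOC(=O)CNC(=O)NC1=CS(=O)(=O)O[C@@]12[C@@H](CO[Si](C)(C)C(C)(C)C)O[C@@H](n1cc(C)c(=O)n(C)c1=O)[C@@H]2O[Si](C)(C)C(C)(C)C`: in this assay compound 2 gives 13000 nM.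
- Compound 3 `Cc1cn([C@@H]2O[C@@H]3COC(=O)[C@]3(OS(C)(=O)=O)[C@H]2O)c(=O)[nH]c1=O`: in this assay compound 3 gives >= 36000 nM, which is a limit of the assay.

For the measured compounds named here, compound 1 stands at the limit of > 200000 nM in this assay, at which 1 of the 3 values shown sits; the assay reports no number for it, only that more compound than this was tolerated. Going by the values given here, the one measured step that starts from compound 1 is an at least 15-fold lower number from compound 1 to compound 2 (1.18 log units; beyond the scatter), and it alters the amine side chain.

Compound 4 `COC(=O)CCNC1=CS(=O)(=O)O[C@@]12[C@@H](CO[Si](C)(C)C(C)(C)C)O[C@@H](n1cc(C)c(=O)n(C)c1=O)[C@@H]2O[Si](C)(C)C(C)(C)C` differs from compound 1 as follows: (methoxycarbonyl)methyl in place of (methoxycarbonyl)carbonyl on a saturated chain carbon bound to an amine nitrogen. The chain keeps its length and its ester end, but one carbonyl is gone. The step from compound 1 to compound 2 shows that a changed side chain can move the number well beyond the scatter, yet that step swapped in a carbamoyl group, whereas here only a carbonyl leaves. Among the compounds with values here, no measured pair mirrors this change exactly.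

The expectation is that compound 4 stays close to compound 1, so an at least 1.3-fold lower number from compound 1 to compound 4 (0.12 log units; that floor lies within the scatter) is estimated to be within the scatter. Compound 4 is therefore expected to give about 150000 nM, between 40000 nM and 300000 nM, quite possibly again as a limit.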

Compound 4, half-maximal cytotoxic concentration: 94000 nM
Estimate against measurement, compound 4: 1.6-fold (0.20 log units) above; measured number inside the range.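

In this assay, the loss of one carbonyl from the side chain on the amine nitrogen, with the chain length and ester end kept, gives an at least 2.1-fold lower number from compound 1 to compound 4 (0.32 log units; beyond the scatter), so a small edit at this position is enough to move the number beyond the scatter. Set against the larger exchange at the same nitrogen, 2-(methoxycarbonyl)ethyl gives a 7.2-fold higher number from compound 2 to compound 4 (0.86 log units; beyond the scatter), which places compound 4 clearly apart from compound 2 and shows that the group carrying the carbamoyl goes with less compound tolerated. The first of these steps gives only a minimum size, since compound 1 is recorded solely as a limit: the limit of > 200000 nM in this assay, at which 1 of the 4 values shown sits.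

The compounds shown leave open whether a free carboxylic acid in place of the methyl ester, or a longer chain on the amine nitrogen, would raise or lower the number. They also leave open which part of the ((ethoxycarbonyl)methyl)carbamoyl group goes with the lower number in compound 2, and they give no measured reason for either step.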